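The source may report more compounds than this note shows. Statements on the series, on what has been measured and on what is new or still open speak of the compounds shown alone.

Series notes. Compound 1 `CC(O)Cn1nnc(-c2ccccc2-c2ccc(CN3C(=O)[C@H](NC(=O)CC(C)(C)N)CCc4ccccc43)cc2)n1` gives 0.05 uM in a functional assay (Pituitary gland cell) with Rattus norvegicus as the target; a higher number here means that more compound is needed for the effect, a lower number that less compound is needed. Compound 2 `CC(C)(N)CC(=O)N[C@@H]1CCc2ccccc2N(Cc2ccc(-c3ccccc3S(=O)(=O)NC(C)(C)C)cc2)C1=O` gives 4 uM in this assay, the higher of the two numbers, the step being an 80-fold higher number from compound 1 to compound 2 (1.90 log units; beyond the scatter). Compound 3 `Cc1ccccc1-c1ccc(CN2C(=O)[C@H](NC(=O)CC(C)(C)N)CCc3ccccc32)cc1` is not yet measured; the change from compound 2 is methyl in place of (tert-butyl)sulfamoyl on an aromatic carbon. Among the measured compounds shown here, no measured step touches the methyl; the one step shows that this position carries large swings. With the hydrogen-bond donor and acceptors of the sulfamoyl removed, compound 3 is expected to give 10 uM, within 1.5 uM to 60 uM. The expected step is a 2.5-fold higher number from compound 2 to compound 3 (0.40 log units; beyond the scatter).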

Compound 3, concentration for half-maximal effect: 1 uM
The estimate for compound 3 lay 10-fold (1.00 log units) above the measured number; measured number outside the range, below it.
By their numbers in this assay, from the lowest: compound 1; then compound 3; then compound 2.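

In this assay, the step of a 4.0-fold lower number from compound 2 to compound 3 (0.60 log units; beyond the scatter) shows that the (tert-butyl)sulfamoyl is not required at this aromatic carbon, since the single methyl gives the lower number. The step of a 20-fold higher number from compound 1 to compound 3 (1.30 log units; beyond the scatter) keeps the 2-(2-hydroxypropyl)-2H-tetrazol-5-yl well ahead, so the methyl falls between the two larger groups and group size alone does not order the three compounds. No available evidence accounts for this order.

Open, on these data alone, is how a carboxylic acid or an unsubstituted tetrazole on this carbon would compare with compound 1. Also open, as far as these compounds go, is whether the hydroxypropyl chain contributes to the low number of compound 1.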